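The compounds below may be only part of what the source reports. "The series", "measured", "known", "first", "only" and "open" are said of these compounds alone.

Compound 2 `CN(C)CCCOc1ccc(CN2CC[C@H](NC(=O)c3ccco3)C2)cc1` is known in an assay on HEK293 cells for binding affinity to Urotensin-2 receptor (Homo sapiens), read by radioligand binding (on this read-out lower numbers stand for stronger inhibition and higher numbers for weaker inhibition), only through a limit, namely < 10000 nM. Its closest measured neighbour, compound 1 `COc1ccc(C(=O)N[C@H]2CCN(Cc3ccc(OCCCN(C)C)cc3)C2)cc1OC`, likewise shows only a limit in this assay, namely < 10000 nM. The step that the two limits leave unreadable from compound 1 to compound 2 therefore cannot be sized, because of the limit of < 10000 nM in this assay, at which 2 of the 2 values shown sit. Compound 3 `CN(C)CCCOc1ccc(CN2CC[C@H](NC(=O)c3ccc4ccccc4c3)C2)cc1` carries naphthalen-2-yl in place of furan-2-yl on a carbonyl carbon. For the measured compounds named here, no measured step bears on this change, and the single step at hand is unreadable, so no shift beyond the scatter is expected; the estimated step is a step that the limit leaves unreadable from compound 2 to compound 3. For compound 3 the expected value in this assay is 2000 nM, within 200 nM to 10000 nM, with a substantial chance that only a limit is reported.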

Compound 3, inhibition constant: < 10000 nM
Compound 3 was reported as a limit; the forecaster's own chance of this, stated with the estimate: 60%; the middle value does not contradict the limit.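

For the compounds shown here, no step among compound 1, compound 2 and compound 3 can be read in this assay, because each value is only a limit: the limit of < 10000 nM in this assay, at which 3 of the 3 values shown sit. From the compounds shown here alone, whether furan-2-yl, naphthalen-2-yl and 3,4-dimethoxyphenyl on the carbonyl carbon differ at all, and by how much, remains open.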